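From 4-bromobenzyl to 4-chlorobenzyl in the series

The source may report more compounds than this note shows. Statements on the series, on what has been measured and on what is new or still open speak of the compounds shown alone.

In a functional assay on HepG2 cells (Homo sapiens) for antiproliferative activity, read by MTT assay, with a stated time of 24 h (a higher number here means a weaker inhibitor, a lower number a stronger inhibitor), compound 1 (`C=CCOc1ccc2c(=O)c(-c3cc(OC)c(OC)cc3OC)coc2c1`) gives 3450 nM, compound 2 (`C#CCOc1ccc2c(=O)c(-c3cc(OC)c(OC)cc3OC)coc2c1`) gives 4950 nM and compound 3 (`COc1cc(OC)c(-c2coc3cc(OCc4ccc(Br)cc4)ccc3c2=O)cc1OC`) gives 1050 nM, the lowest number of the three. Compound 4 (`COc1cc(OC)c(-c2coc3cc(OCc4ccc(Cl)cc4)ccc3c2=O)cc1OC`) has chloro in place of bromo on an aromatic carbon, para to a large group: chloro in place of bromo on an aromatic carbon. Among the compounds with values here, no measured step exchanges one halogen for another. The nearest evidence is indirect: a 1.4-fold higher number from compound 1 to compound 2 (0.16 log units; within the scatter), a 3.3-fold lower number from compound 1 to compound 3 (0.52 log units; beyond the scatter) and a 4.7-fold lower number from compound 2 to compound 3 (0.67 log units; beyond the scatter). The two larger steps replace a whole vinyl or ethynyl with 4-bromophenyl, a far greater change, and are still modest. The expected change in this assay is therefore none beyond the scatter, with an estimated 1.1-fold higher number from compound 3 to compound 4 (0.06 log units; within the scatter). Compound 4 is estimated at 1200 nM, with an expected range of 550 nM to 2600 nM.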

Compound 4, half-maximal inhibitory concentration: 940 nM
The estimate for compound 4 lay 1.3-fold (0.11 log units) above the measured number; the measured number falls inside the stated range.
By their numbers in this assay, from the lowest: compounds 4 and 3 (each within the scatter of the next); then compounds 1 and 2 (each within the scatter of the next).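

In this assay, exchanging the halogen on the aromatic carbon, para to a large group, gives no change beyond the scatter: a 1.1-fold lower number from compound 3 to compound 4 (0.05 log units; within the scatter). The lower numbers relative to the small groups also hold with chloro in place of bromo: a 5.3-fold lower number from compound 2 to compound 4 (0.72 log units; beyond the scatter) and a 3.7-fold lower number from compound 1 to compound 4 (0.56 log units; beyond the scatter). No measurement shown here accounts for these numbers.

On these data alone, whether the halogen is needed at all remains open. An unsubstituted benzyl, a 4-methoxybenzyl or a chain ending in an amine would test how far this position tolerates change.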